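Bromo to Nitro on a Second Core, Growth Inhibition

The compounds below may be only part of what the source reports. "The series", "measured", "known", "first", "only" and "open" are said of these compounds alone.

The study measures growth inhibition in a functional assay on MCF7 cells (Homo sapiens) for inhibition, read by sulforhodamine B assay, with a stated time of 48 h; on this read-out higher numbers stand for weaker inhibition of growth and lower numbers for stronger inhibition of growth. Compound 1 `N#CCC1=C(C#N)CC(c2ccc([N+](=O)[O-])cc2)=C(CC(=O)c2ccc([N+](=O)[O-])cc2)O1` gives 30 nM in this assay, and compound 2 `N#CCC1=C(C#N)CC(c2ccc([N+](=O)[O-])cc2)=C(CC(=O)c2ccc(Br)cc2)O1` gives 4900 nM. The two share one core and differ at a single point: nitro in place of bromo on an aromatic carbon. That change produced a 160-fold lower number from compound 2 to compound 1 (2.21 log units; beyond the scatter).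

Compound 3 `N#CCC1=NN=C(c2ccc(Br)cc2)C(Br)O1` is built on a different core; the difference between the two cores is not broken down here. In this assay compound 3 gives 70700 nM, the highest of the three numbers, with compound 2 nearest and compound 1 furthest away.

Compound 4 `N#CCC1=NN=C(c2ccc([N+](=O)[O-])cc2)C(Br)O1` has not yet been measured. It stands to compound 3 as compound 1 stands to compound 2: nitro in place of bromo on an aromatic carbon. The place described for this change is the same as in the earlier pair, so it counts as the same change, made this time on the core of compound 3.

Whether the second core answers the change as the first did is not known from the compounds shown; only one earlier instance exists. Compound 4 is therefore expected to fall below compound 3 by a 14-fold lower number from compound 3 to compound 4 (1.15 log units; beyond the scatter), a step assumed smaller than the earlier one because a 160-fold lower number from compound 2 to compound 1 (2.21 log units; beyond the scatter) was seen on a different core and may not carry over in full. The estimate for compound 4 in this assay is 5000 nM, with a range from 500 nM to 40000 nM.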

Compound 4, concentration for 50% growth inhibition: 10600 nM
For compound 4 the middle estimate is 2.1-fold (0.33 log units) below the measured one; low and high end bracket the measured number.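

In this assay the second core answers nitro in place of bromo on an aromatic carbon in the same direction as the first, with a 6.7-fold lower number from compound 3 to compound 4 (0.82 log units; beyond the scatter) on the core of compound 3. The direction of the change therefore carries over in this one further case, but its size does not, and the two steps cannot be treated as one transferable increment: the same change on two cores in this assay, a 160-fold lower number (2.21 log units; beyond the scatter) from compound 2 to compound 1 and a 6.7-fold lower number (0.82 log units; beyond the scatter) from compound 3 to compound 4, 24-fold (1.39 log units) apart, beyond the scatter of two such steps. This does not show what sets the size of the step on either core, and with only two instances it gives no general rule for a third core, which might show a step close to either of these, one of a different size, or none at all.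

The compounds shown leave open whether other groups in that same place, such as an amine, a carboxylic acid or a longer chain, would also differ in size from one core to the other. They also leave open how much of the gap between the two steps depends on the rest of each core, including the second bromo that compound 3 and compound 4 both keep.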